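From allyl to 2-(methoxycarbonyl)ethyl at the weak end

This account rests on a few compounds, and the source may have more. Where it says the series, first, only, none or still open, it means among the compounds named here.

In a functional assay on WiDr cells (Homo sapiens) for antiproliferative activity, read by sulforhodamine B assay, with a stated time of 48 h (a lower number here means a stronger inhibitor of growth, a higher number a weaker inhibitor of growth), compound 1 `CC(C)(C)[Si](C)(C)O[C@@H]1CCCO[C@@H]1CO` reads > 100000 nM, which is a limit of the assay and not a number. Compound 2 `O=C(COC[C@H]1OCCC[C@H]1O)OCc1ccccc1` reads > 100000 nM, again a limit. Within the data shown here, compound 3 `C=CCOC[C@H]1OCCC[C@H]1O[Si](C)(C)C(C)(C)C` gives 88000 nM, the only true number among the three, and it stands close to the limit of > 100000 nM in this assay, at which 2 of the 3 values shown sit.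

Compound 4 `COC(=O)CCOC[C@H]1OCCC[C@H]1O[Si](C)(C)C(C)(C)C` differs from compound 3 by carrying (methoxycarbonyl)methyl in place of vinyl on a saturated chain carbon bound to an oxygen on a saturated carbon. The same difference can be read as allyl to 2-(methoxycarbonyl)ethyl.

Among the measured compounds shown here, only one measured step bears on this change: an at least 1.1-fold lower number from compound 1 to compound 3 (0.05 log units; that floor lies within the scatter). That step introduces the allyl group that is now altered, and its size is bounded only from one side. It gives no sign of a large effect from this chain in this assay, so no step beyond the scatter is expected here, and a reading that reports only the limit remains quite possible. An estimated 1.0-fold lower number from compound 3 to compound 4 (0.02 log units; within the scatter) is expected. For compound 4 the expected value is 85000 nM, with an estimated range of 45000 nM to 150000 nM.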

Compound 4, concentration for 50% growth inhibition: > 100000 nM
Compound 4: a limit, no number (the forecaster's own chance of this, stated with the estimate: 40%); middle value at least 1.1-fold (0.07 log units) from the limit.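

In this assay, the change from allyl to 2-(methoxycarbonyl)ethyl gives an at least 1.1-fold higher number from compound 3 to compound 4 (0.05 log units; that floor lies within the scatter), so bringing in this ester chain, with its 2 hydrogen-bond acceptors, gives no sign of stronger growth inhibition at this place. Compound 4 reads > 100000 nM, which is a limit of the assay and not a number. The step from compound 1 to compound 4 cannot be read, and compound 3 remains the only compound here with a true number, while the set as a whole now sits even more firmly at the ceiling: the limit of > 100000 nM in this assay, at which 3 of the 4 values shown sit.

The compounds shown leave open how far compound 4 lies from that limit, so the true size of the change from allyl to 2-(methoxycarbonyl)ethyl stays unknown. They also leave open whether a carboxylic acid or an amine at the end of this chain, or a longer chain on the same oxygen, would give a true number clear of the limit.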